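Removing the Ethoxy Group from a Trialkoxy Pyridyl Chalcone

The source may hold more compounds than are shown below. What is called first, only, known or untested is meant among the compounds shown, and "the series" means these compounds.

Measured compounds:
Compound 1 `CCOc1c(OC)cc(/C=C/C(=O)c2ccncc2)cc1OC` — 230 nM
Compound 2 `COc1ccccc1/C=C/C(=O)c1ccncc1` — 570 nM
Compound 3 `CCOc1cc(/C=C/C(=O)c2ccncc2)cc(OC)c1OCC` — 65 nM

Of the compounds shown here, three sharing one core have been measured in an assay on cell membranes for inhibition of cytochrome P450 1A1 (Homo sapiens), read by fluorescence, using microsomes, with a stated time of 10 min; a lower number here means a stronger inhibitor, a higher number a weaker inhibitor. Compound 1 gives 230 nM, which is the second highest of the three numbers: compound 2 at 570 nM sits above it, and compound 3 at 65 nM sits below it. Among the measured compounds shown here, the only single-point step among them, a 3.5-fold lower number from compound 1 to compound 3 (0.55 log units; beyond the scatter), shows that a methyl in place of hydrogen on a saturated chain carbon bound to an oxygen on an aromatic ring lowered the number.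

Compound 4 `COc1cc(/C=C/C(=O)c2ccncc2)cc(OC)c1` differs from compound 1 by hydrogen in place of ethoxy on an aromatic carbon. For the measured compounds named here, no measured step removes an alkoxy group outright, so the step is not directly anchored. Going by the values given here, the one step that does bear on it, a 3.5-fold lower number from compound 1 to compound 3 (0.55 log units; beyond the scatter), ran toward lower numbers as the alkoxy groups grew, and compound 2, with a single methoxy, gives the highest number of the three. Compound 4 is therefore expected to move in the opposite direction, toward a higher number, with a modest step of a 2.6-fold higher number from compound 1 to compound 4 (0.42 log units; beyond the scatter). The estimate for compound 4 in this assay is 600 nM, within a range from 250 nM to 1500 nM.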

Compound 4, half-maximal inhibitory concentration: 180 nM
Beside the measured number, compound 4's estimate is 3.3-fold (0.52 log units) above it; the whole stated range lies above it.
By their numbers in this assay, from the lowest: compound 3; then compounds 4 and 1 (each within the scatter of the next); then compound 2.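

In this assay the change of ethoxy to hydrogen, on an aromatic carbon ortho to two methoxy groups and para to a large group, gives a 1.3-fold lower number from compound 1 to compound 4 (0.11 log units; within the scatter) and so separates the two compounds by no more than the usual scatter. The whole ethoxy group can therefore go from this position with no readable effect on the number. A change at one of the methoxy groups comes with a 3.5-fold lower number from compound 1 to compound 3 (0.55 log units; beyond the scatter), so the two alkoxy sites do not respond alike. No supporting measurement is available to explain this result.

As far as these compounds go, whether an amine, a hydroxyl group or a longer chain at this position would match hydrogen and ethoxy remains open. So does whether hydrogen and ethoxy would still match if the methoxy groups were changed.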